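A few compounds are considered here, and "the series" means these few. Any claim that something is new, unique, unknown or untested is made for them only; others in the source may bear on it.

Measured compounds:
- compound 1 `OC[C@H]1O[C@@H](n2cnc3c(NCc4ccc(Cl)cc4Cl)ncnc32)[C@H](O)[C@@H]1O` gives 127000 nM in a functional assay on MCF cells (Homo sapiens) for antiproliferative activity, with a stated time of 72 h; on this read-out lower numbers stand for stronger inhibition and higher numbers for weaker inhibition
- compound 2 `COc1cc(CNc2ncnc3c2ncn3[C@@H]2O[C@H](CO)[C@@H](O)[C@H]2O)cc(OC)c1O` reaches only the limit > 166000 nM in this assay
- compound 3 `OC[C@H]1O[C@@H](n2cnc3c(NCc4ccccc4C(F)(F)F)ncnc32)C(O)C1O` likewise reaches only the limit > 166000 nM in this assay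

Among the measured compounds shown here, compound 1 is the one member of this set with a measured number rather than a limit; the other two sit at the limit of > 166000 nM in this assay, at which 2 of the 3 values shown sit. Its own value lies close to that limit, so it is a weak inhibitor in this assay.

Compound 4 `OC[C@H]1O[C@@H](n2cnc3c(NCc4ccc(C(F)(F)F)cc4)ncnc32)[C@H](O)[C@@H]1O` has not been measured. It differs from compound 1 in one place: 4-(trifluoromethyl)phenyl in place of 2,4-dichlorophenyl on a saturated chain carbon bound to a nitrogen on an aromatic ring. No measured pair in this set isolates the effect of that exchange, so the step from compound 1 to compound 4 cannot be read off any shown step.

Given that compound 1 itself gives 127000 nM in this assay and is a weak inhibitor there, compound 4 is expected to remain in the same weak region, with a 1.2-fold higher number from compound 1 to compound 4 (0.07 log units; within the scatter) expected to be no larger than the scatter in either direction. Compound 4 is therefore estimated at 150000 nM, between 60000 nM and 300000 nM, with a fair chance that this assay reports only a limit for it.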

Compound 4, half-maximal inhibitory concentration: > 166000 nM
Compound 4: no number, only a limit; the forecaster's own chance of this, stated with the estimate: 45%; middle value at least 1.1-fold (0.04 log units) away from the limit.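

In this assay compound 4 reaches only a limit, > 166000 nM, and not a number. Exchanging the 2,4-dichlorophenyl on the saturated chain carbon for 4-(trifluoromethyl)phenyl therefore gives a step known only as a floor, an at least 1.3-fold higher number from compound 1 to compound 4 (0.11 log units; that floor lies within the scatter), the first step read at this position. The exchange does not lift the compound out of the weak region, and compound 4 joins the compounds held at the limit: the limit of > 166000 nM in this assay, at which 3 of the 4 values shown sit.

As far as these compounds go, the true size of the step stays open, as does whether any group at this position can give a number clearly lower than that of compound 1. The compounds shown cannot tell what an amine or a carboxylic acid on the phenyl ring, or a longer chain carrying that ring, would do in this assay.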